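The source may hold more compounds than are shown below. What is called first, only, known or untested is meant among the compounds shown, and "the series" means these compounds.

Measured in a functional assay on A2780 cells (Homo sapiens) for antiproliferative activity, read by MTT assay, with a stated time of 48 h; on this read-out lower numbers stand for stronger inhibition and higher numbers for weaker inhibition:

- Compound 1 `C=C(c1cc(OC)c(OC)c(OC)c1)c1ccc(OC)cc1NC(=O)CO`: 30 nM
- Compound 2 `C=C(c1cc(OC)c(OC)c(OC)c1)c1ccc(OC)cc1NC(=O)CN`: 30 nM
- Compound 3 `C=C(c1cc(OC)c(OC)c(OC)c1)c1ccc(OC)cc1NC(=O)CNC`: 140 nM

Compound 3, at 140 nM, has the highest number of the three in this assay, and it is weaker than both others beyond the scatter. Compound 4 `C=C(c1cc(OC)c(OC)c(OC)c1)c1ccc(OC)cc1NC(=O)CNCC` has not yet been measured. It carries methyl in place of hydrogen on a saturated chain carbon bound to an amine nitrogen, so methylamino becomes ethylamino: methyl in place of hydrogen on a saturated chain carbon bound to an amine nitrogen.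

Among the measured compounds shown here, the closest precedent is the addition of methyl in place of hydrogen on the amine nitrogen, a 4.7-fold higher number from compound 2 to compound 3 (0.67 log units; beyond the scatter), a modest loss. The exchange of hydroxy for amino, no change at the digits printed from compound 1 to compound 2 (within the scatter), shows no change, and a 4.7-fold higher number from compound 1 to compound 3 (0.67 log units; beyond the scatter) matches the loss seen with the methyl addition. For the measured compounds named here, with only one step on the amine as a guide, a further modest rise in the number is expected, probably no larger than that precedent. The expected step is a 1.9-fold higher number from compound 3 to compound 4 (0.27 log units; within the scatter). Compound 4 is estimated at 260 nM. The estimated range for compound 4 runs from 100 nM to 650 nM.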

Compound 4, half-maximal inhibitory concentration: 450 nM
Compound 4: middle estimate off by 1.7-fold (0.24 log units), on the low side; low and high end bracket the measured number.
By their numbers in this assay, from the lowest: compounds 1 and 2 (each within the scatter of the next); then compound 3; then compound 4.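

In this assay the change from methylamino to ethylamino brought a 3.2-fold higher number from compound 3 to compound 4 (0.51 log units; beyond the scatter) and so a second loss on this side chain, which shows that the rise in the number does not end with the first methyl on the amine nitrogen. Ethyl in place of hydrogen on the amine nitrogen gives a 15-fold higher number from compound 2 to compound 4 (1.18 log units; beyond the scatter) and so a large loss, and ethylamino in place of hydroxy gives a 15-fold higher number from compound 1 to compound 4 (1.18 log units; beyond the scatter) and a loss of the same printed size, so the number climbs with each added carbon across compounds 2, 3 and 4. No measurement at hand explains this loss.

As far as these compounds go, whether a propyl or isopropyl chain on this nitrogen would continue the climb remains open. So does how a dimethylamino group, a morpholine ring or a carboxylic acid in place of the amine would compare.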